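Hydroxyl for Methyl on the Triazole Chain: Cytotoxicity Expectation

The compounds below may be only part of what the source reports. "The series", "measured", "known", "first", "only" and "open" are said of these compounds alone.

Compound 1 `CCCCCCCc1cn(C(c2ccccc2)c2cc3cc(Br)ccc3nc2OC)nn1` gives 4.42% in an ADME assay on PC-3 cells (Homo sapiens) for cytotoxicity, read by sulforhodamine B assay, with a stated time of 48 h, tested at 10 uM; a lower number here means less inhibition, a higher number more inhibition at the concentration tested (going by the name of the read-out). Compound 2 `CCCCc1cn(C(c2ccccc2)c2cc3cc(Br)ccc3nc2OC)nn1` gives 5.54%. Compound 3 `CCCc1cn(C(c2ccccc2)c2cc3cc(Br)ccc3nc2OC)nn1` gives 8.3%.

Compound 3 holds the top number of the three, yet the steps to compound 2 and compound 1 are both within the scatter, so the three compounds cannot be told apart. Compound 4 `COc1nc2ccc(Br)cc2cc1C(c1ccccc1)n1cc(CCO)nn1` differs from compound 3 by hydroxy in place of methyl on a saturated chain carbon, two bonds along the chain from an aromatic carbon. Among the compounds with values here, no measured step swaps in a hydroxy; the known steps of a number 1.1 percentage points higher from compound 1 to compound 2 (within the scatter), a number 3.9 percentage points higher from compound 1 to compound 3 (within the scatter) and a number 2.8 percentage points higher from compound 2 to compound 3 (within the scatter) only shorten the chain on the triazole and all lie within the scatter. On that footing no shift beyond the scatter is expected for compound 4, and its expected step is a number 0.3 percentage points lower from compound 3 to compound 4 (within the scatter). The estimate for compound 4 in this assay is 8%, in the range 0% to 20%.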

Compound 4, a percentage reported as inhibition, at one concentration (the size of the read-out at that concentration, not a potency): 15.5%
For compound 4 the middle estimate is 7.5 percentage points below the measured one; the measured number falls inside the stated range.
By their numbers in this assay, from the lowest: compounds 1, 2, 3 and 4 (each within the scatter of the next, the first and the last beyond it).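

The hydroxy in place of methyl at this chain position gives a rise within the scatter (a number 7.2 percentage points higher from compound 3 to compound 4 (within the scatter)) in this assay, and the same holds against the next longer chain (a number 10 percentage points higher from compound 2 to compound 4 (within the scatter)). Only the comparison with the heptyl chain of compound 1 clears the scatter (a number 11.1 percentage points higher from compound 1 to compound 4 (beyond the scatter)), the first separation in this short set, and a modest one. No supporting measurement explains this result.

Still open, as far as these compounds go, is whether the hydroxy itself matters or only the shorter chain, which a longer chain ending in hydroxy could help separate. An amine or a carboxylic acid at the same chain end would show whether other groups behave alike.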